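A few compounds are considered here, and "the series" means these few. Any claim that something is new, unique, unknown or untested is made for them only; others in the source may bear on it.

Measured compounds:
- compound 1, `Clc1ccc(Nc2nc3c(N4CCCC4)ncnc3s2)cc1` — 4260 nM
- compound 2, `OC[C@@H]1CCCN1c1ncnc2sc(Nc3ccc(Cl)cc3)nc12` — 934 nM
- compound 3, `OC[C@@H]1CCCN1c1ncnc2sc(Nc3cccc(Br)c3)nc12` — 1070 nM

All three were tested in an assay on CHO cells for displacement of a labelled ligand from adenosine receptor A3 (Homo sapiens), read by scintillation counting, with a stated time of 3 h; on this read-out lower numbers stand for stronger inhibition and higher numbers for weaker inhibition. Compound 2 gives the smallest number of the three, but its gap to compound 3, a 1.1-fold higher number from compound 2 to compound 3 (0.06 log units; within the scatter), is within the scatter, so these two cannot be told apart. Only compound 1 stands clearly apart: the step of a 4.6-fold lower number from compound 1 to compound 2 (0.66 log units; beyond the scatter) is beyond the scatter.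

Compound 4, `CN(C)c1ncnc2sc(Nc3ccc(Cl)cc3)nc12`, has not yet been measured. It differs from compound 2 in one place: dimethylamino in place of 2-(hydroxymethyl)pyrrolidin-1-yl on an aromatic carbon. For the measured compounds named here, the only measured step that bears on this change is a 4.6-fold lower number from compound 1 to compound 2 (0.66 log units; beyond the scatter), where adding the hydroxymethyl to the saturated ring lowered the number. Compound 4 loses that hydroxymethyl and the five-membered ring with it, keeping only a dimethylamino at that position. Nothing measured here shows how the ring itself matters, so the expectation rests on that single step.

Because of a 4.6-fold lower number from compound 1 to compound 2 (0.66 log units; beyond the scatter), the number for compound 4 is expected to rise relative to compound 2, by roughly a 5.4-fold higher number from compound 2 to compound 4 (0.73 log units; beyond the scatter), landing near or a little beyond compound 1. The estimated value for compound 4 is 5000 nM, with a range from 1500 nM to 15000 nM.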

Compound 4, inhibition constant: > 10000 nM
Compound 4: no number, only a limit; the forecaster's own chance of this, stated with the estimate: 10%; at least 2.0-fold (0.30 log units) between middle value and limit.
By their numbers in this assay, from the lowest: compounds 2 and 3 (each within the scatter of the next); then compound 1. At a limit, above all of these: compound 4.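

In this assay compound 4 gives only a limit, not a number: the limit of > 10000 nM in this assay, at which 1 of the 4 values shown sits. Even so, the limit shows how much this aromatic carbon next to the ring nitrogen tolerates, since replacing 2-(hydroxymethyl)pyrrolidin-1-yl with dimethylamino gives an at least 10-fold higher number from compound 2 to compound 4 (1.02 log units; beyond the scatter), a larger step than the one earlier seen on removing the hydroxymethyl alone. For the compounds shown here, the comparison without any hydroxymethyl on either side, an at least 2.3-fold higher number from compound 1 to compound 4 (0.37 log units; beyond the scatter), adds something the earlier compounds could not show: the five-membered ring matters in its own right, so opening it to dimethylamino moves the result beyond the scatter even when the hydroxymethyl plays no part.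

Going by these compounds, the real number for compound 4 remains unknown, so the full size of both steps stays open, and so does whether the ring matters as a ring or only through the carbons it carries. A six-membered piperidine at this carbon, or an open-chain amine such as 2-hydroxyethylamino that keeps a hydroxyl without any ring, would help to separate the contribution of the ring from that of the hydroxyl.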